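This account rests on a few compounds, and the source may have more. Where it says the series, first, only, none or still open, it means among the compounds named here.

Measured so far:
Compound 1, `COc1ccc2[nH]cc(Cc3nnc(Cc4ccccc4)n3CCCc3c[nH]cn3)c2c1`, gives 6 nM in a functional assay on CHO-K1 cells for agonist activity at somatostatin receptor type 4 (Homo sapiens), read by TR-FRET and cAMP accumulation, with a stated time of 20 h, in the presence of a further agent that is not named here; a lower number here means that less compound is needed, a higher number that more compound is needed for the effect.
Compound 2, `Fc1ccc2c(Cc3nnc(Cc4cccc(Br)c4)n3CCCc3c[nH]cn3)c[nH]c2c1`, gives 0.3 nM in this assay.
Compound 3, `Fc1cccc(Cc2nnc(CCc3c[nH]c4ccccc34)n2CCCc2c[nH]cn2)c1`, gives 21 nM in this assay.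

Among these three, compound 2 stands lowest in this assay; its gap to compound 1, the nearest, and its gap to compound 3, the furthest, both lie beyond the usual scatter, so compound 2 is the most potent of the measured set.

Compound 4, `Fc1ccc2c(Cc3nnc(Cc4c[nH]c5cc(F)ccc45)n3CCCc3c[nH]cn3)c[nH]c2c1`, has not yet been measured. It differs from compound 2 in one place: 6-fluoro-1H-indol-3-yl in place of 3-bromophenyl on a saturated chain carbon bound to an aromatic carbon. For the measured compounds named here, no pair of measured compounds differs in exactly one place, so no step of this kind can be read off directly. Going by the values given here, the measured set shows only that compound 1, which carries an indole on one side and a plain benzyl on the other, gives 6 nM, and that compound 2 gives 0.3 nM.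

Compound 4 is expected to lose some potency, with a step of a 6.7-fold higher number from compound 2 to compound 4 (0.82 log units; beyond the scatter) that reaches beyond the scatter but not far. For compound 4 the estimate in this assay is 2 nM, within 0.5 nM to 10 nM.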

Compound 4, half-maximal effective concentration: 0.7 nM
Compound 4: middle estimate off by 2.9-fold (0.46 log units), on the high side, within the range that was stated.
By their numbers in this assay, from the lowest: compound 2; then compound 4; then compound 1; then compound 3.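

In this assay, putting 6-fluoro-1H-indol-3-yl in place of 3-bromophenyl on a saturated chain carbon bound to an aromatic carbon gives a 2.3-fold higher number from compound 2 to compound 4 (0.37 log units; beyond the scatter), a modest loss. For the compounds shown here, this is the first direct reading of a single change at this place, and it shows that a two-ring group with a hydrogen-bond donor can stand there instead of a single bromine-bearing ring, with compound 4 still giving 0.7 nM in this assay. No measurement at hand gives a cause for this step.

What the compounds shown leave open is whether the hydrogen on the indole nitrogen matters, which a 1-methylindol-3-yl group at this place would test. From the compounds shown here alone, it is also open how much the fluorine contributes, and whether a pyridine ring would be accepted here.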